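Methoxy removal on the aryl ketone of compound 2

The source may report more compounds than this note shows. Statements on the series, on what has been measured and on what is new or still open speak of the compounds shown alone.

Compound 2 `COc1ccc(-c2cc(/C=C/C(=O)c3ccc(OC)c(OC)c3)nc3cc(-c4ccccc4)nn23)cc1` gives 48500 nM in an ADME assay on HEK293 cells (Homo sapiens) for antiproliferative activity, read by MTT assay, with a stated time of 24 h (a lower number here means a stronger inhibitor, a higher number a weaker inhibitor), the second highest of the three numbers measured. Compound 3 `COc1ccc(-c2cc(/C=C/C(=O)c3ccc(C)c(C)c3)nc3cc(-c4ccccc4)nn23)cc1OC` gives 46200 nM in this assay, the nearest to compound 2 and within the scatter of it; compound 1 `COc1ccc(-c2cc(C(=O)/C=C/c3ccccc3)nc3cc(-c4ccccc4)nn23)cc1OC` gives 64100 nM in this assay, the furthest, also within the scatter. For the measured compounds named here, the only single-point step among the measured compounds, a 1.4-fold lower number from compound 1 to compound 3 (0.14 log units; within the scatter), exchanges the whole arm attached to the shared core and still stays within the scatter, so the set so far contains no step beyond the scatter. Compound 4 `COc1ccc(C(=O)/C=C/c2cc(-c3ccc(OC)cc3)n3nc(-c4ccccc4)cc3n2)cc1` differs from compound 2 by hydrogen in place of methoxy on an aromatic carbon. Going by the values given here, no measured pair isolates the loss of one methoxy from this ring; the step from compound 1 to compound 3, which changes more than that, is the closest guide and was flat. The step of a 1.0-fold higher number from compound 2 to compound 4 (0.01 log units; within the scatter) is therefore expected to stay within the scatter. The estimate for compound 4 in this assay is 50000 nM, with a range from 28000 nM to 90000 nM.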

Compound 4, half-maximal inhibitory concentration: 36100 nM
Estimate against measurement, compound 4: 1.4-fold (0.14 log units) above; the range from low to high includes it.
By their numbers in this assay, from the lowest: compounds 4, 3, 2 and 1 (each within the scatter of the next).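

In this assay, for the compounds shown here, the first comparison to isolate a single group on this ring, 3,4-dimethoxyphenyl to 4-methoxyphenyl on the ketone, gives a 1.3-fold lower number from compound 2 to compound 4 (0.13 log units; within the scatter). The methoxy ortho to a methoxy group can therefore be replaced by hydrogen with no change beyond the scatter, and this pair cannot be told apart in this assay. Nothing available explains this flat result.

Open, as far as these compounds go, is whether this position responds to anything other than these two groups, such as a hydroxyl, a fluorine or a dimethylamino group in place of the hydrogen of compound 4. Also open, from the compounds shown here alone, is whether the remaining methoxy on the ketone ring of compound 4 can be replaced by hydrogen as well, giving an unsubstituted phenyl ketone.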